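From chloro to hydroxy: one swap, one open value

This account rests on a few compounds, and the source may have more. Where it says the series, first, only, none or still open, it means among the compounds named here.

Compound 1 `O=S(=O)(Nc1cccc2cc(O)[nH]c12)c1ccc(Cl)cc1` 4.5 ug/mL
Compound 2 `O=[N+]([O-])c1ccc(S(=O)(=O)Nc2cccc3cc(Cl)[nH]c23)cc1` 19 ug/mL

In a functional assay on MC-38 cells (Mus musculus) for antiproliferative activity, read by colorimetric assay and MTT assay (a lower number here means a stronger inhibitor, a higher number a weaker inhibitor), compound 2 has the higher of the two numbers, which makes it the weaker inhibitor, and its gap to compound 1 lies beyond the usual scatter. Compound 3 `O=[N+]([O-])c1ccc(S(=O)(=O)Nc2cccc3cc(O)[nH]c23)cc1` differs from compound 2 in one place (hydroxy in place of chloro on an aromatic carbon): hydroxy in place of chloro on an aromatic carbon. Compound 1 carries that hydroxy and gives 4.5 ug/mL but also differs from compound 2 elsewhere, so the data cannot isolate this swap. The expected step of a 2.4-fold lower number from compound 2 to compound 3 (0.38 log units; beyond the scatter) is a modest fall in the number in this assay and may only just clear the scatter. For compound 3 the estimated value is 8 ug/mL (expected range 3 ug/mL to 20 ug/mL).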

Compound 3, half-maximal inhibitory concentration: 62 ug/mL
For compound 3 the middle estimate is 7.8-fold (0.89 log units) below the measured one, outside the stated range (above it).
By their numbers in this assay, from the lowest: compound 1; then compound 2; then compound 3.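

In this assay, hydroxy in place of chloro on the aromatic carbon next to the ring nitrogen gives a 3.3-fold higher number from compound 2 to compound 3 (0.51 log units; beyond the scatter) when nitro is present, so this swap does not help here. With hydroxy kept, nitro in place of chloro gives a 14-fold higher number from compound 1 to compound 3 (1.14 log units; beyond the scatter), a large step, which shows that the change away from this position also matters strongly. No measurement here explains either step. Still open, going by these compounds, is how an amine would behave at the position next to the ring nitrogen, and whether hydroxy in place of chloro would step the same way in compounds carrying chloro instead of nitro.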